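The compounds below may be only part of what the source reports. "The series", "measured", "known", "first", "only" and "open" are said of these compounds alone.

Compound 1 `C=C/C=C\[C@H](C)[C@H](OC(N)=O)[C@@H](C)[C@H](O)[C@@H](C)C/C(C)=C\[C@H](C)[C@@H](O)[C@@H](C)/C=C\CCc1ccc(Oc2ccccc2)cc1`: 10000 nM
Compound 2 `C=C/C=C\[C@H](C)[C@H](OC(N)=O)[C@@H](C)[C@H](O)[C@@H](C)C/C(C)=C\[C@H](C)[C@@H](O)[C@@H](C)/C=C\CCc1cccc(Cl)c1`: 580 nM

In a functional assay on A549 cells (Homo sapiens) for cytotoxicity (a lower number here means a stronger inhibitor, a higher number a weaker inhibitor), compound 1 gives 10000 nM and compound 2 holds the lower of the two numbers at 580 nM. The gap separating these two compounds lies beyond the scatter. Compound 3 `C=C/C=C\[C@H](C)[C@H](OC(N)=O)[C@@H](C)[C@H](O)[C@@H](C)C/C(C)=C\[C@H](C)[C@@H](O)[C@@H](C)/C=C\CCc1ccsc1` keeps the core of compound 2 and changes only the end of the chain: thiophen-3-yl in place of 3-chlorophenyl on a saturated chain carbon, two bonds along the chain from a double-bonded chain carbon. Thiophen-3-yl thus replaces 3-chlorophenyl on a saturated chain carbon. For the measured compounds named here, no measured pair shows this swap, so the expectation in this assay is only a modest rise, within the scatter. The estimated change is a 1.4-fold higher number from compound 2 to compound 3 (0.14 log units; within the scatter). For compound 3, the estimated value is 800 nM, with an expected range of 250 nM to 3000 nM.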

Compound 3, half-maximal inhibitory concentration: 4000 nM
Compound 3: middle estimate off by 5.0-fold (0.70 log units), on the low side, and the stated range ends below it.
By their numbers in this assay, from the lowest: compound 2; then compound 3; then compound 1.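

In this assay, the swap of 3-chlorophenyl for thiophen-3-yl gives a 6.9-fold higher number from compound 2 to compound 3 (0.84 log units; beyond the scatter) with the rest of the molecule unchanged. For the compounds shown here, this is the first direct evidence that the group at the end of the chain matters to the read-out, and the smaller thiophen-3-yl ring does not keep the level of 3-chlorophenyl. Nothing available here explains the rise.

The swap changes both the ring and the chlorine at once, so their separate contributions cannot be told apart. An unsubstituted phenyl or a thiophen-2-yl group at this position remains an open case.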